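The source may hold more compounds than are shown below. What is called first, only, known or untested is meant among the compounds shown, and "the series" means these compounds.

Working notes on a small set of hydroxyphenyl-substituted compounds sharing one core, read in an ADME assay on HEK293 cells (Homo sapiens) for cytotoxicity, read by CCK-8 assay, with a stated time of 4 days; on this read-out higher numbers stand for weaker inhibition and lower numbers for stronger inhibition. Compound 1 `Oc1ccc(-c2cc(-c3ccccc3O)cc(-c3ccccc3O)n2)cc1` gives 6990 nM in this assay. Compound 2 `Oc1ccc(-c2cc(-c3cccc(O)c3)nc(-c3ccccc3O)c2)cc1` gives 7420 nM in this assay. On the numbers shown, compound 2 sits beside compound 1, the two values lying within the usual scatter of each other, so no order between them is claimed. No step between measured compounds that differ in one place is available, and no cause for any difference can be read from two compounds alone.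

Compound 3 `Oc1ccc(-c2cc(-c3ccc(O)cc3)nc(-c3ccccc3O)c2)cc1` is the next compound and is not yet measured. It differs from compound 2 by one change: 4-hydroxyphenyl in place of 3-hydroxyphenyl on an aromatic carbon. The two compounds have the same atoms, joined differently. For this assay no step beyond the scatter is expected, since compound 1 and compound 2 carry different arrangements of the same hydroxyphenyl groups and still fall together. Compound 3 is therefore estimated at 7500 nM, with a range from 3500 nM to 16000 nM. The step this estimate means is a 1.0-fold higher number from compound 2 to compound 3 (0.00 log units; within the scatter), expected to lie within the scatter.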

Compound 3, half-maximal inhibitory concentration: 26300 nM
Compound 3: middle estimate off by 3.5-fold (0.54 log units), on the low side, and the stated range ends below it.
By their numbers in this assay, from the lowest: compounds 1 and 2 (each within the scatter of the next); then compound 3.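

In this assay, 4-hydroxyphenyl in place of 3-hydroxyphenyl on the aromatic carbon next to the ring nitrogen gives a 3.5-fold higher number from compound 2 to compound 3 (0.55 log units; beyond the scatter), so the placing of the hydroxyl on this ring can move the read-out, which compound 1 and compound 2, lying within the scatter of each other, did not show. The other single exchange, a 2-hydroxyphenyl group giving way to a 4-hydroxyphenyl group, gives a 3.8-fold higher number from compound 1 to compound 3 (0.58 log units; beyond the scatter), in the same direction towards weaker inhibition, so compound 3 stands apart from both earlier compounds even though the atoms of the exchanged groups and the counted donors and acceptors stay the same. No measurement at hand bears on why this rearrangement changes the number.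

Whether the hydroxyl itself matters at the place next to the ring nitrogen remains open, since the compounds shown carry only hydroxyphenyl groups there and none with a methoxy group, an amine or a plain phenyl ring. Also open, from the compounds shown here alone, is whether the step from compound 2 to compound 3 would hold with the 2-hydroxyphenyl group of the shared core replaced.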